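Compound 4 in the diacyl thioglycerol cysteinyl amide series

The compounds below may be only part of what the source reports. "The series", "measured", "known", "first", "only" and "open" are said of these compounds alone.

Measured compounds:
compound 1, `CCCCCCCCCCCC(=O)OC[C@H](CSC[C@@H](N)C(=O)N[C@@H](C)CO)OC(=O)CCCCCCCCCCC`, 1560 nM
compound 2, `CCCCCCCCCCCC(=O)OC[C@H](CSC[C@@H](N)C(=O)NC(C)CCc1ccccc1)OC(=O)CCCCCCCCCCC`, 160 nM
compound 3, `CCCCCCCCCCCC(=O)OC[C@H](CSC[C@@H](N)C(=O)NC(C)c1ccc(O)cc1)OC(=O)CCCCCCCCCCC`, 2890 nM

In an assay on HEK293 cells for agonist activity at Toll-like receptor 2 (Homo sapiens) (a lower number here means that less compound is needed, a higher number that more compound is needed for the effect), compound 3 gives the highest of the three numbers. Its nearest neighbour is compound 1; the step of a 1.9-fold higher number from compound 1 to compound 3 (0.27 log units; within the scatter) stays within the scatter. The step of an 18-fold higher number from compound 2 to compound 3 (1.26 log units; beyond the scatter) is the large one of the set, and the step of a 9.8-fold lower number from compound 1 to compound 2 (0.99 log units; beyond the scatter) is modest.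

Compound 4, `CCCCCCCCCCCC(=O)OC[C@H](CSC[C@@H](N)C(=O)NC(CC)COC)OC(=O)CCCCCCCCCCC`, is not yet measured. Relative to compound 3 the change is 1-(methoxymethyl)propyl in place of 1-(4-hydroxyphenyl)ethyl on an amide-type nitrogen. The shared core, the amide and the thioether linkage are untouched; only the substituent on the amide nitrogen differs.

Within the data shown here, the step from compound 1 to compound 3, read in reverse, is the closest precedent: a small chain with one oxygen in place of the hydroxyphenyl group moved the number within the scatter. The large step from compound 2 to compound 3 concerns a phenethyl group and does not apply directly, since compound 4 carries no ring. A lower number than compound 3 is therefore expected, at the edge of the scatter, giving for compound 4 the estimate 1200 nM with a range of 400 nM to 3600 nM, that is the expected step of a 2.4-fold lower number from compound 3 to compound 4 (0.38 log units; beyond the scatter).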

Compound 4, half-maximal effective concentration: 71.8 nM
The estimate for compound 4 lay 17-fold (1.22 log units) above the measured number; the measured number lies below the stated range.
By their numbers in this assay, from the lowest: compound 4; then compound 2; then compounds 1 and 3 (each within the scatter of the next).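

In this assay, a substituent with no ring on the amide-type nitrogen can give the lowest number of the four: 1-(methoxymethyl)propyl brings a 40-fold lower number from compound 3 to compound 4 (1.60 log units; beyond the scatter) and a 22-fold lower number from compound 1 to compound 4 (1.34 log units; beyond the scatter). Among these compounds, compound 2 had been the only low number and carries a phenyl ring, yet a 2.2-fold lower number from compound 2 to compound 4 (0.35 log units; beyond the scatter) shows that such a ring is not required here. No evidence at hand accounts for these steps.

1-(methoxymethyl)propyl and 1-(hydroxymethyl)ethyl differ in both the ether oxygen and the chain length, so the compounds shown do not separate these two changes. Open, going by these compounds, is whether 1-(hydroxymethyl)propyl, which has a free hydroxyl on the same chain, or a longer chain ending in methoxy would keep the number of compound 4 in this assay.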